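A few compounds are considered here, and "the series" means these few. Any claim that something is new, unique, unknown or untested is made for them only; others in the source may bear on it.

Measured compounds in the series:

compound 1 `FC(F)(F)C(F)(F)C(F)(F)C(F)(F)C(F)(F)C(F)(F)CCn1cc(COc2ccccc2-c2nc3ccccc3s2)nn1` — in a functional assay on A549 cells (Homo sapiens) for cytotoxicity, read by MTT assay, with a stated time of 24 h (a lower number here means a stronger inhibitor, a higher number a weaker inhibitor), compound 1 gives 15100 nM
compound 2 `Fc1ccc(-n2cc(COc3ccccc3-c3nc4ccccc4s3)nn2)cc1Cl` — in this assay compound 2 gives 16300 nM
compound 3 `Brc1ccc(-c2cc(COc3ccccc3-c3nc4ccccc4s3)on2)cc1` — in this assay compound 3 gives 19200 nM

All three share the same core, carrying a heptafluoro-type chain, a halogenated phenyl on a triazole, or a bromophenyl on an isoxazole. Within this assay the three numbers lie close together. Compound 2 sits second highest of the three; its nearest neighbour is compound 1, its furthest is compound 3, and both gaps fall within the scatter, so no order among them can be read.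

Compound 4 `Fc1ccc(-n2cc(COc3ccccc3-c3nc4ccccc4s3)nn2)cc1` is not yet measured. It differs from compound 2 in one place: hydrogen in place of chloro on an aromatic carbon — hydrogen in place of chloro on an aromatic carbon, ortho to a fluoro group and meta to a large group, which reads as 3-chloro-4-fluorophenyl turned into 4-fluorophenyl.

For the measured compounds named here, no step between measured compounds covers the loss of a chloro group, so the size of the step in this assay cannot be taken from the data. Given that compounds 1, 2 and 3 differ widely at this position of the core and still return numbers within the scatter of each other, a change of one chlorine is expected to produce no step beyond the scatter, with a slight lean toward a higher number. The expected step is a 1.1-fold higher number from compound 2 to compound 4 (0.04 log units; within the scatter). Compound 4 is estimated at 18000 nM in this assay, within the range 9000 nM to 40000 nM.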

Compound 4, half-maximal inhibitory concentration: 23300 nM
Beside the measured number, compound 4's estimate is 1.3-fold (0.11 log units) below it, and the stated range covers the measured number.
By their numbers in this assay, from the lowest: compounds 1, 2, 3 and 4 (each within the scatter of the next).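

In this assay, for the compounds shown here, the change from 3-chloro-4-fluorophenyl to 4-fluorophenyl gives a 1.4-fold higher number from compound 2 to compound 4 (0.16 log units; within the scatter) and is the first reading of a change in one place. At this aromatic carbon, ortho to a fluoro group and meta to a large group, hydrogen can therefore stand in place of chloro without a step that can be told from the scatter, although this rests on a single pair of compounds. No data bearing on the reason for this result are at hand.

From the compounds shown here alone, whether any other group on this carbon, such as methoxy, an amine or a carboxylic acid, would give a step beyond the scatter remains open. Also open, going by these compounds, are the outcome of replacing the fluoro group of compound 4 with hydrogen and whether the loss of a halogen reads the same on the bromophenyl of compound 3, where the triazole of compound 2 is replaced by an isoxazole.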